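Imidazole for Pyrazole on a Shared Core: Expected Clearance

A few compounds are considered here, and "the series" means these few. Any claim that something is new, unique, unknown or untested is made for them only; others in the source may bear on it.

Three compounds share a core and differ only in the group on one aromatic carbon. In an ADME assay on microsomes from liver (Homo sapiens) for metabolic stability, read by LC-MS, using NADPH, with stated times of 5 min and 30 min, tested at 1 uM (a higher number here means faster removal of the compound, a lower number slower removal), compound 1 `CN(c1ccn(C)n1)c1cnc(NCc2c(F)ccc3c2CCO3)c2cn[nH]c(=O)c12` gives 62 mL.min-1.g-1, compound 2 `Cn1cc(-c2cnc(NCc3c(F)ccc4c3CCO4)c3cn[nH]c(=O)c23)cn1` gives 21 mL.min-1.g-1, and compound 3 `Cn1nccc1-c1cnc(NCc2c(F)ccc3c2CCO3)c2cn[nH]c(=O)c12` gives 14 mL.min-1.g-1. Compound 3 therefore stands at the low end of the three numbers: its gap to compound 2 is within the scatter, while compound 1 lies beyond it, a 4.4-fold lower number from compound 1 to compound 3 (0.65 log units; beyond the scatter). The step of a 3.0-fold lower number from compound 1 to compound 2 (0.47 log units; beyond the scatter) is of similar size, whereas the swap between the two pyrazolyl groups, a 1.5-fold lower number from compound 2 to compound 3 (0.18 log units; within the scatter), stays within the scatter.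

Compound 4 `Cc1ncc(-c2cnc(NCc3c(F)ccc4c3CCO4)c3cn[nH]c(=O)c23)n1C` is not yet measured. It differs from compound 3 by 1,2-dimethyl-1H-imidazol-5-yl in place of 1-methyl-1H-pyrazol-5-yl on an aromatic carbon. For the measured compounds named here, the only measured step that exchanges one small ring for another attached in the same way, a 1.5-fold lower number from compound 2 to compound 3 (0.18 log units; within the scatter), was within the scatter, and no measured pair brings in a 1,2-dimethyl-1H-imidazol-5-yl group. The steps from compound 1 remove a methyl(1-methyl-1H-pyrazol-3-yl)amino group and so bear less directly on this change. On that basis compound 4 is expected to show a 1.1-fold higher number from compound 3 to compound 4 (0.06 log units; within the scatter), no step beyond the scatter. Compound 4 is estimated at 16 mL.min-1.g-1 in this assay, with a range from 7 mL.min-1.g-1 to 35 mL.min-1.g-1.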

Compound 4, intrinsic clearance in microsomes: 10 mL.min-1.g-1
Compound 4: middle estimate off by 1.6-fold (0.20 log units), on the high side, and the stated range covers the measured number.
By their numbers in this assay, from the lowest: compounds 4, 3 and 2 (each within the scatter of the next, the first and the last beyond it); then compound 1.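

In this assay the 1,2-dimethyl-1H-imidazol-5-yl group cannot be told apart from the 1-methyl-1H-pyrazol-5-yl group, with a 1.4-fold lower number from compound 3 to compound 4 (0.15 log units; within the scatter) showing that this position tolerates a different ring with a second methyl without a readable shift. Against compound 2 the reading differs: a 2.1-fold lower number from compound 2 to compound 4 (0.32 log units; beyond the scatter) is the first exchange of one directly attached ring for another to pass the scatter, whereas a 1.5-fold lower number from compound 2 to compound 3 (0.18 log units; within the scatter) did not. For the compounds shown here, with a 6.2-fold lower number from compound 1 to compound 4 (0.79 log units; beyond the scatter) as the largest step so far, all three compounds carrying a ring directly on this carbon now lie beyond the scatter from compound 1, and none of the four goes against that.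

The compounds shown do not separate the effect of the imidazole ring from that of its added methyl, and they leave open how a 1-methyl-1H-imidazol-5-yl group, a pyridine ring or a simple amine on this carbon would read in this assay on the shared core. Nothing available here accounts for why the numbers fall as they do.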